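The compounds below may be only part of what the source reports. "The series", "measured", "known", "first", "only" and "open" are said of these compounds alone.

Among the measured compounds shown here, compound 2 `CC1=C(C(=O)O[C@@H](C)CO[N+](=O)[O-])[C@@H](c2cccc3nonc23)C([N+](=O)[O-])=C(C)C1` holds the lower of the two numbers so far: in a functional assay (ileum) for antagonist activity, with Cavia porcellus as the target (on this read-out higher numbers stand for weaker inhibition and lower numbers for stronger inhibition), compound 2 gives 577 nM, whereas compound 1 `CC1=C(C(=O)OC(C)CO[N+](=O)[O-])C(c2cccc3nonc23)C([N+](=O)[O-])=C(C)C1` gives 6380 nM. The step of an 11-fold lower number from compound 1 to compound 2 (1.04 log units; beyond the scatter) is read in the light of the fact that one of compounds 1 and 2 is drawn with a defined configuration and the other without, at the place where they differ. Compound 3 `CC1=C(C(=O)O[C@H](C)CO[N+](=O)[O-])[C@@H](c2cccc3nonc23)C([N+](=O)[O-])=C(C)C1` differs from compound 2 as follows: the two compounds have the same atoms and bonds and differ only in configuration as drawn: 1 of 2 stereo elements differ; a stereocentre at a saturated chain carbon is drawn S in compound 2 and R in compound 3. For the measured compounds named here, only the step from compound 1 to compound 2 bears on this change; compound 1, drawn without configuration at both centres, gives the higher number, so the remaining isomers within it are likely weaker inhibitors. A moderate upward step is expected, a 3.1-fold higher number from compound 2 to compound 3 (0.49 log units; beyond the scatter). Compound 3 is therefore estimated at 1800 nM, within 500 nM to 7000 nM.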

Compound 3, half-maximal inhibitory concentration: 59.6 nM
Compound 3: the middle estimate sits 30-fold (1.48 log units) above what was measured; measured number below the stated range.
By their numbers in this assay, from the lowest: compound 3; then compound 2; then compound 1.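

With the saturated ring carbon drawn R in both, changing the saturated chain carbon from S to R gives a 9.7-fold lower number from compound 2 to compound 3 (0.99 log units; beyond the scatter) in this assay. The sample drawn without configuration lies further off, with a 110-fold lower number from compound 1 to compound 3 (2.03 log units; beyond the scatter). The chain stereocentre therefore shifts the number on its own, with atoms and bonds unchanged: the fact that compounds 2 and 3 differ only in the configuration as drawn

On these data alone, how the isomers with the saturated ring carbon drawn S behave, with either chain configuration, stays open. So does whether the preference for R at the chain carbon survives replacing the nitrate ester with an amine or using a longer chain.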